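A methyl replaced by hydrogen: compound 1 to compound 4

The compounds below may be only part of what the source reports. "The series", "measured", "known", "first", "only" and "open" are said of these compounds alone.

Measured in a functional assay on U-373MG ATCC cells (Homo sapiens) for cytotoxicity, read by MTT assay, with a stated time of 72 h; on this read-out lower numbers stand for stronger inhibition and higher numbers for weaker inhibition:
- compound 1 `Cc1ccc2[nH]c(-n3cccn3)c(C3=C(Br)C(=O)NC3=O)c2c1` gives 27000 nM
- compound 2 `COc1ccc2[nH]c3c4cn[nH]c4c4c(c3c2c1)C(=O)NC4=O` gives 51000 nM
- compound 3 `COc1ccc2[nH]c(-n3cccn3)cc2c1` gives > 100000 nM

In this assay the numbers for compound 1 and compound 2 lie within the usual scatter of each other, so the two cannot be told apart. Compound 1 therefore shares its standing with compound 2 and has no clear lead. The entry for compound 3 is a limit and not a number.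

Compound 4 `O=C1NC(=O)C(c2c(-n3cccn3)[nH]c3ccccc23)=C1Br` has not yet been measured. It differs from compound 1 in one place: hydrogen in place of methyl on an aromatic carbon. In words, hydrogen stands in place of methyl on an aromatic carbon of a six-membered aromatic ring of carbon only. Going by the values given here, no measured pair of compounds shows this change on its own, so the data give no direct size for it. Among the compounds with values here, with only this small change from compound 1 at 27000 nM, no shift beyond the scatter is expected, and neither direction is favoured. The expected change is a 1.2-fold higher number from compound 1 to compound 4 (0.07 log units; within the scatter). For compound 4 the estimate is 32000 nM, with an expected range from 12000 nM to 85000 nM.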

Compound 4, half-maximal inhibitory concentration: 27000 nM
Beside the measured number, compound 4's estimate is 1.2-fold (0.07 log units) above it; low and high end bracket the measured number.
By their numbers in this assay, from the lowest: compounds 1, 4 and 2 (each within the scatter of the next). At a limit, above all of these: compound 3.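

In this assay the methyl of compound 1 can be replaced by hydrogen with no change at the digits printed from compound 1 to compound 4 (within the scatter). Going by these compounds alone, the earlier compounds held no pair that isolated this aromatic carbon, so this step is the only direct reading of it, and it shows that the methyl is not needed to keep the cytotoxicity at the level of compound 1. Compound 3 alone stands at a limit, which is not a number, and neither end of this step does, so the step can be read as it is printed: the limit of > 100000 nM in this assay, at which 1 of the 4 values shown sits.

The compounds shown leave open how this carbon of the six-membered aromatic ring would respond to a group other than methyl or hydrogen, such as an amine, a carboxylic acid or a longer alkyl chain, in this assay. Going by these compounds, the finding also rests on a single pair in a single cell line, so whether hydrogen and methyl would also read alike on another core or in other cells remains unknown.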